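This account rests on a few compounds, and the source may have more. Where it says the series, first, only, none or still open, it means among the compounds named here.

Compound 1 `O=S(=O)(NCCCNCc1cccc2ccccc12)c1cc(C(F)(F)F)cc(C(F)(F)F)c1`: in a functional assay on MCF7 cells (Homo sapiens) for inhibition, read by MTT assay, with a stated time of 72 h (on this read-out higher numbers stand for weaker inhibition of growth and lower numbers for stronger inhibition of growth), compound 1 gives 1400 nM.
Compound 2 `O=S(=O)(NCCCNCc1cccc(Cl)c1)c1cc(C(F)(F)F)cc(C(F)(F)F)c1`: in this assay compound 2 gives 2600 nM.

Among these two numbers, compound 2 has the higher one, but the only measured step, a 1.9-fold higher number from compound 1 to compound 2 (0.27 log units; within the scatter), lies within the scatter, so the two compounds cannot be told apart on these data. That step exchanges one aromatic group for another on the saturated chain carbon bound to the amine nitrogen, and the read-out barely moves.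

Compound 3 `COc1ccccc1CNCCCNS(=O)(=O)c1cc(C(F)(F)F)cc(C(F)(F)F)c1` differs from compound 2 in a single place: 2-methoxyphenyl in place of 3-chlorophenyl on a saturated chain carbon bound to an amine nitrogen. The change again swaps one aromatic group for another at the same position. Going by the values given here, no measured pair matches this exact exchange, so the only guide is the step from compound 1 to compound 2, which stayed within the scatter. On that basis no shift beyond the scatter is expected in this assay, and the step from compound 2 to compound 3 is estimated as a 1.2-fold higher number from compound 2 to compound 3 (0.06 log units; within the scatter). Compound 3 is therefore expected to give about 3000 nM, with a likely range from 1200 nM to 8000 nM.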

Compound 3, concentration for 50% growth inhibition: 2600 nM
Beside the measured number, compound 3's estimate is 1.2-fold (0.06 log units) above it, within the range that was stated.
By their numbers in this assay, from the lowest: compounds 1, 2 and 3 (each within the scatter of the next).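

In this assay, the place on a saturated chain carbon bound to an amine nitrogen now has a third aromatic group: 2-methoxyphenyl in place of 3-chlorophenyl gives no change at the digits printed from compound 2 to compound 3 (within the scatter) and 2-methoxyphenyl in place of naphthalen-1-yl gives a 1.9-fold higher number from compound 1 to compound 3 (0.27 log units; within the scatter) in the same read-out. The entering group has oxygen where the group it replaces in compound 2 has chlorine, and it adds a hydrogen-bond acceptor, yet neither step leaves the scatter, so these three aromatic groups cannot be told apart at this position on these data. No separate measurement bears on why the read-out stays so flat here.

From the compounds shown here alone, all three compounds carry an aromatic ring at this place, so it remains open whether the read-out would hold with a non-aromatic group such as cyclohexyl, or with a carboxylic acid on the ring. Also open, going by these compounds, is whether a longer chain in the shared core would shift the number beyond the scatter, which would show whether other parts of the molecule matter more than this one.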